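Aminophenyl position in the thiazolidinedione series

A few compounds are considered here, and "the series" means these few. Any claim that something is new, unique, unknown or untested is made for them only; others in the source may bear on it.

compound 1 `Nc1cccc(/C=C2\SC(=O)N(Cc3cccc(Cl)c3)C2=O)c1` — 195000 nM
compound 2 `Cc1ccc(CN2C(=O)S/C(=C\c3cccc(N)c3)C2=O)cc1` — > 250000 nM, a limit of the assay
compound 3 `Nc1ccc(/C=C2\SC(=O)N(Cc3ccc(Cl)cc3)C2=O)cc1` — 87000 nM

In a functional assay on CCRF-CEM cells (Homo sapiens) for cytotoxicity, read by cell counting, with a stated time of 3 days (on this read-out higher numbers stand for weaker inhibition and lower numbers for stronger inhibition), compound 3 gives 87000 nM, the lowest of the two numbers; the nearest is compound 1 at 195000 nM, beyond the scatter. Compound 2 sits at the limit of > 250000 nM in this assay, at which 1 of the 3 values shown sits.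

Compound 4 `Nc1cccc(/C=C2\SC(=O)N(Cc3ccc(Cl)cc3)C2=O)c1` is not yet measured; it differs from compound 3 by 3-aminophenyl in place of 4-aminophenyl on a double-bonded chain carbon bound to a double-bonded ring carbon. Within the data shown here, the only measured step, an at least 1.2-fold higher number from compound 1 to compound 2 (0.10 log units; that floor lies within the scatter), alters the group on the ring nitrogen and does not touch the aminophenyl, so no measured step covers this change. Among the measured compounds shown here, compounds 1 and 3 differ in two places, and their values show only that the pair carrying 3-aminophenyl gives the higher number.

Compound 4 is therefore expected between those two, at 130000 nM (60000 nM to 250000 nM). That expectation means a step of a 1.5-fold higher number from compound 3 to compound 4 (0.17 log units; within the scatter).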

Compound 4, half-maximal inhibitory concentration: > 250000 nM
Compound 4: no number, only a limit (the forecaster's own chance of this, stated with the estimate: 20%); middle value at least 1.9-fold (0.28 log units) from the limit.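

In this assay, the aminophenyl position now has a step of its own with the 4-chlorophenyl group held fixed: 3-aminophenyl in place of 4-aminophenyl on the double-bonded chain carbon is beyond the scatter (an at least 1.2-fold higher number from compound 1 to compound 4 (0.10 log units; that floor lies within the scatter) is the other readable step, and it settles nothing about the chlorine position, whereas an at least 2.8-fold higher number from compound 3 to compound 4 (0.45 log units; beyond the scatter) does settle this change). The step between compound 2 and compound 4 cannot be read. Compound 4 gives a limit, not a number: the limit of > 250000 nM in this assay, at which 2 of the 4 values shown sit.

Open, as far as these compounds go, is whether a carboxylic acid or a longer chain in place of the amine gives a number under that limit. Also open, from the compounds shown here alone, is whether 4-aminophenyl keeps its lower number with 3-chlorophenyl or 4-methylphenyl on the saturated chain carbon.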